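The source may hold more compounds than are shown below. What is called first, only, known or untested is meant among the compounds shown, and "the series" means these compounds.

In a functional assay on the whole organism with Mus musculus as the target (on this read-out higher numbers stand for an effect only at larger amounts of compound and lower numbers for an effect already at smaller amounts), compound 1 `CCCCN1C(=O)CCC1(O)c1cccc(C(F)(F)F)c1` gives > 200 mg/kg as a limit and not as a number. Compound 2 `CN(C)C(=O)CCC(=O)c1cccc(C(F)(F)F)c1` gives > 50 mg/kg as a limit as well. Compound 3 `CC(C)NC(=O)CCC(=O)c1cccc(C(F)(F)F)c1` gives > 200 mg/kg and this too is only a limit. Going by the values given here, compound 3 therefore stands at the limit of > 200 mg/kg in this assay, at which 2 of the 3 values shown sit, and no compound in the set has yet given a number.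

The next structure is compound 4 `CCC(C)NC(=O)CCC(=O)c1cccc(C(F)(F)F)c1` and its difference from compound 3 is methyl in place of hydrogen on a saturated chain carbon, two bonds along the chain from an amide-type nitrogen in words: methyl in place of hydrogen on a saturated chain carbon, two bonds along the chain from an amide-type nitrogen, which turns isopropylamino into (sec-butyl)amino.

Among the compounds with values here, the one measured step on this part of the structure is a step that the two limits leave unreadable from compound 2 to compound 3 and it gives neither a size nor a direction. Within the data shown here, no measured step covers the added methyl itself. Among the measured compounds shown here, the only anchor is compound 3 with its limit of > 200 mg/kg for the expectation that follows. No step beyond the scatter is therefore expected in this assay and no direction can be assigned. The estimated size is a number no higher from compound 3 to compound 4 (the limit leaves the size open) and a further limit is the likeliest report. For compound 4 the expected value is 200 mg/kg with an estimated range of 100 mg/kg to 400 mg/kg as the outcome.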

Compound 4, dose for half-maximal effect: > 200 mg/kg
Compound 4: only a limit was reported (the forecaster's own chance of this, stated with the estimate: 75%); the middle value lies on the limit itself.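

Compound 4 is reported only as a limit, as are compound 2 and compound 3, and the steps from compound 2 and from compound 3 to compound 4 cannot be read in this assay. The compounds shown leave open at what dose compound 2, compound 3 or compound 4 would reach half-maximal effect, and whether methyl in place of hydrogen changes that dose at all.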